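Aryl swap on the amide carbonyl of compound 2

This account rests on a few compounds, and the source may have more. Where it says the series, first, only, none or still open, it means among the compounds named here.

Compound 2 `O=C(NCN1CCC(c2cccc[n+]2[O-])CC1)c1ccc(F)c(Cl)c1` stands second highest of the three numbers in a functional assay on HEK293 cells for agonist activity at D(4) dopamine receptor (Homo sapiens), read by FLIPR (a lower number here means a smaller maximal response, a higher number a larger maximal response), where compound 2 gives 67%. Its nearest neighbour is compound 3 `Cc1cccc(Cl)c1NC(=O)CN1CCC(c2ccccn2)CC1`, which gives 70%, within the scatter of compound 2. Furthest is compound 1 `O=C(NCN1CCC(c2cccc[n+]2[O-])CC1)c1cnccc1Cl`, which gives 44%; the one measured step, a number 23 percentage points higher from compound 1 to compound 2 (beyond the scatter), is a modest rise beyond the scatter.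

Compound 4 `Cc1cc(C)cc(C(=O)NCN2CCC(c3cccc[n+]3[O-])CC2)c1` is not yet measured. Its change from compound 2 is 3,5-dimethylphenyl in place of 3-chloro-4-fluorophenyl on a carbonyl carbon. For the measured compounds named here, the only measured step that bears on this is a number 23 percentage points higher from compound 1 to compound 2 (beyond the scatter), which also exchanged the aromatic group on the carbonyl carbon and moved the number by a modest amount. That step compares 4-chloropyridin-3-yl with 3-chloro-4-fluorophenyl and gives no indication of how 3,5-dimethylphenyl will sit relative to either. Compound 3 carries a different core and does not inform this exchange. The expected step of a number 2 percentage points lower from compound 2 to compound 4 (within the scatter) is therefore small and of uncertain direction, most likely within the scatter. For compound 4 the estimate is 65%, with a range from 45% to 85%.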

Compound 4, largest response reached (reported as efficacy), in percent of the reference or control that the assay uses: 56%
Compound 4: the middle estimate sits 9 percentage points above what was measured, and the stated range covers the measured number.
By their numbers in this assay, from the lowest: compound 1; then compound 4; then compounds 2 and 3 (each within the scatter of the next).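

In this assay the position on the carbonyl carbon proves sensitive even to an exchange that leaves the counted features alike: 3,5-dimethylphenyl and 3-chloro-4-fluorophenyl have the same heavy-atom count, a six-membered aromatic ring of carbon only, no hydrogen-bond donors or acceptors and no net charge, yet the change gives a number 11 percentage points lower from compound 2 to compound 4 (beyond the scatter) and so the maximal response here depends on more than those counted features. Against the 4-chloropyridin-3-yl group, the same 3,5-dimethylphenyl group gives a number 12 percentage points higher from compound 1 to compound 4 (beyond the scatter), so among these three compounds both carbon-only aromatic rings stand above the pyridine-containing group, while the two carbon-only rings still differ from each other beyond the scatter. No evidence is available on what lies behind these differences.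

The compounds shown leave open whether the halogens or the positions of the substituents set the difference between the two carbon-only rings, which a 3,5-dichlorophenyl group at the same carbonyl carbon would separate. Also open, on these data alone, is how an unsubstituted phenyl group would compare with all three aromatic groups on the shared core.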